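A Phenyl Swap on the Piperazine Sulfonamide

This account rests on a few compounds, and the source may have more. Where it says the series, first, only, none or still open, it means among the compounds named here.

Measured so far:
- compound 1, `CCCn1c(=O)c2[nH]c(-c3ccc(S(=O)(=O)N4CCN(c5ccc(Cl)cc5)CC4)cc3)nc2n(CC)c1=O`: 28%
- compound 2, `CCCn1c(=O)[nH]c2nc(-c3ccc(S(=O)(=O)N4CCN(c5cccc(F)c5)CC4)cc3)[nH]c2c1=O`: 44%
- compound 3, `CCCn1c(=O)c2[nH]c(-c3ccc(S(=O)(=O)N4CCN(c5ccc(Cl)cc5)CC4)cc3)nc2n(C)c1=O`: 39%

All three were tested in an assay on CHO cells for displacement of a labelled ligand from adenosine receptor A3 (Homo sapiens), read by scintillation counting, with a stated time of 45 min, tested at 1 uM, in the presence of a further agent that is not named here; a lower number here means less inhibition, a higher number more inhibition at the concentration tested (going by the name of the read-out). Among the three numbers, compound 2 has the highest; its gap from compound 3 lies within the usual scatter, while its gap from compound 1 lies beyond it. For the measured compounds named here, the only measured step that changes one place, a number 11 percentage points higher from compound 1 to compound 3 (beyond the scatter), concerns the shared core and not the ring on the piperazine nitrogen.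

The unmeasured compound 4, `CCCn1c(=O)[nH]c2nc(-c3ccc(S(=O)(=O)N4CCN(c5ccccc5C)CC4)cc3)[nH]c2c1=O`, differs from compound 2 in exactly that ring: 2-methylphenyl in place of 3-fluorophenyl on an amine nitrogen in a ring. Going by the values given here, no measured step touches this position, so nothing here tells how large an effect to expect in this assay, in either direction. The plainest expectation is therefore a number near that of compound 2, with a wide range. Compound 4 is expected to give about 42%, between 22% and 62%. The step of a number 2 percentage points lower from compound 2 to compound 4 (within the scatter) implied by this estimate is expected to stay within the scatter.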

Compound 4, a percentage reported as inhibition, at one concentration (the size of the read-out at that concentration, not a potency): 25%
Beside the measured number, compound 4's estimate is 17 percentage points above it; measured number inside the range.
By their numbers in this assay, from the lowest: compounds 4 and 1 (each within the scatter of the next); then compounds 3 and 2 (each within the scatter of the next).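

In this assay, for the compounds shown here, the step of a number 19 percentage points lower from compound 2 to compound 4 (beyond the scatter) is the first measured sign that the aromatic ring on this amine nitrogen matters for the read-out. The two rings have the same count of heavy atoms and neither has hydrogen-bond donors or acceptors, yet the swap replaces fluorine with methyl and also changes the number in the group's name, so this single step cannot show which of the two differences counts. No measurement here gives a reason for the lower number.

Still open, as far as these compounds go, is whether plain phenyl, 2-fluorophenyl or 3-methylphenyl on this same core would stay close to compound 2 or to compound 4. From the compounds shown here alone, it is equally open how a ring with nitrogen in it, such as pyridyl, would behave at this position.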